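Notes on a difluorophenyl swap in the series

A few compounds are considered here, and "the series" means these few. Any claim that something is new, unique, unknown or untested is made for them only; others in the source may bear on it.

Measured so far in an ADME assay on MT4 cells (Homo sapiens) for cytotoxicity, read by MTT assay; a higher number here means that more compound is tolerated, a lower number that less compound is tolerated
- compound 1 `Cc1ccc(C(=O)N(C(=S)OCCN2C(=O)c3ccccc3C2=O)c2ccc(Cl)cc2)cc1` gives > 100000 nM (a limit of the assay)
- compound 2 `O=C1c2ccccc2C(=O)N1CCOC(=S)N(C(=O)c1c(F)cccc1F)c1ccc(Cl)cc1` gives 39000 nM

For the measured compounds named here, compound 2 holds the only actual number so far, since the entry for compound 1 is a limit. The change to compound 3 `O=C1c2ccccc2C(=O)N1CCOC(=S)N(C(=O)c1ccc(F)c(F)c1)c1ccc(Cl)cc1` is 3,4-difluorophenyl in place of 2,6-difluorophenyl on a carbonyl carbon and puts 3,4-difluorophenyl in place of 2,6-difluorophenyl on a carbonyl carbon. Going by the values given here, the one measured step at this place is an at least 2.5-fold lower number from compound 1 to compound 2 (0.40 log units; beyond the scatter) and lies beyond the scatter, yet it replaced 4-methylphenyl and gives no firm size for this change. No step beyond the scatter is therefore expected in this assay here. Compound 3 is expected at 45000 nM with an estimated range from 18000 nM to 100000 nM for now. The expected step is a 1.2-fold higher number from compound 2 to compound 3 (0.06 log units; within the scatter) on this estimate.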

Compound 3, half-maximal cytotoxic concentration: 52000 nM
For compound 3 the middle estimate is 1.2-fold (0.06 log units) below the measured one; the measured number falls inside the stated range.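

In this assay, 3,4-difluorophenyl in place of 2,6-difluorophenyl on the carbonyl carbon gives a 1.3-fold higher number from compound 2 to compound 3 (0.12 log units; within the scatter), so the arrangement of the two fluorines does not separate these compounds here. Against 4-methylphenyl the reading is an at least 1.9-fold lower number from compound 1 to compound 3 (0.28 log units; that floor lies within the scatter), so compound 3 does not confirm a real difference from that group. The entry for compound 1 is a limit, not a number: the limit of > 100000 nM in this assay, at which 1 of the 3 values shown sits.

Still open, going by these compounds, is the true size of any difference between 4-methylphenyl and the difluorophenyl groups. Also open, on these data alone, is whether a phenyl group carrying an amine or a carboxylic acid at this place would move the number beyond the scatter.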